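Moving the Side Chain from Compound 3 to Compound 4

A few compounds are considered here, and "the series" means these few. Any claim that something is new, unique, unknown or untested is made for them only; others in the source may bear on it.

Values measured in a functional assay on DU-145 cells (Homo sapiens) for cytotoxicity, read by trypan blue exclusion, with a stated time of 96 h (on this read-out lower numbers stand for stronger inhibition and higher numbers for weaker inhibition), are as follows:
- compound 1 `COc1cc(OC)c(/C=C/S(=O)(=O)Cc2ccc(OC)c([N+](=O)[O-])c2)c(OC)c1` gives 2500 nM
- compound 2 `COc1cc(OC)c(/C=C/S(=O)(=O)Cc2ccc(Br)c([N+](=O)[O-])c2)c(OC)c1` gives 25000 nM
- compound 3 `COC(=O)C(F)(F)Nc1cc(CS(=O)(=O)/C=C/c2c(OC)cc(OC)cc2OC)ccc1OC` gives 250 nM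

Compound 3 holds the lowest number of the three, and both other compounds lie beyond the scatter from it. Compound 4 `COc1cc(OC)c(/C=C/S(=O)(=O)Cc2ccc(OC)c(NCCC(=O)O)c2)c(OC)c1` has not yet been measured. Its difference from compound 3 is 2-carboxyethyl in place of difluoro(methoxycarbonyl)methyl on a nitrogen on an aromatic ring and in words it is 2-carboxyethyl in place of difluoro(methoxycarbonyl)methyl on a nitrogen on an aromatic ring.

The closest evidence is a 10-fold lower number from compound 1 to compound 3 (1.00 log units; beyond the scatter) for (difluoro(methoxycarbonyl)methyl)amino in place of nitro on an aromatic carbon. The other measured step, a 10-fold higher number from compound 1 to compound 2 (1.00 log units; beyond the scatter) for bromo in place of methoxy on an aromatic carbon, is also modest but bears only on the general size of changes. Among the measured compounds shown here, no measured compound carries 2-carboxyethyl. With compound 3 already at 250 nM as the lowest number, a modest upward change is expected, read as a 2.4-fold higher number from compound 3 to compound 4 (0.38 log units; beyond the scatter) in this estimate. The estimate for compound 4 is 600 nM in this assay with 100 nM to 4000 nM as its expected range.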

Compound 4, half-maximal inhibitory concentration: 5000 nM
Estimate against measurement, compound 4: 8.3-fold (0.92 log units) below, outside the stated range (above it).
By their numbers in this assay, from the lowest: compound 3; then compounds 1 and 4 (each within the scatter of the next); then compound 2.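

In this assay, the substituent on this nitrogen proves to matter on its own: 2-carboxyethyl in place of difluoro(methoxycarbonyl)methyl gives a 20-fold higher number from compound 3 to compound 4 (1.30 log units; beyond the scatter), a large step and the only one shown that is made on the nitrogen itself. (2-Carboxyethyl)amino in place of nitro gives a 2.0-fold higher number from compound 1 to compound 4 (0.30 log units; within the scatter), within the scatter, so among these compounds the lower number of compound 3 goes with its particular side chain and not with the nitrogen alone. Nothing in the data shown accounts for this difference.

On these data alone, the two side chains differ in their fluorines, their chain and their end group all at once, so which of these carries the step stays open. A methyl ester on the 2-carboxyethyl chain, or a difluorinated chain ending in a carboxylic acid, would separate them.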